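The compounds below may be only part of what the source reports. "The series", "measured", "known", "first", "only" and "open" are said of these compounds alone.

Measured so far in a functional assay on HCT-116 cells (Homo sapiens) for antiproliferative activity, read by MTT assay, with a stated time of 48 h; a higher number here means a weaker inhibitor, a lower number a stronger inhibitor:
compound 1, `Cc1cnc(Nc2ccc([N+](=O)[O-])cc2)nc1Nc1nc2ccccc2s1`: 6330 nM
compound 2, `Cc1cnc(Nc2ccc(S(N)(=O)=O)cc2)nc1Nc1nc2ccccc2s1`: 1660 nM
compound 3, `Cc1cnc(Nc2ccc(F)cc2)nc1Nc1nc2ccccc2s1`: a limit only

For compound 3 this assay reports no number but a limit, > 50000 nM, (the limit of > 50000 nM in this assay, at which 1 of the 3 values shown sits). Compound 3 thus stands at the weak end of the three: an at least 7.8-fold higher number from compound 1 to compound 3 (0.89 log units; beyond the scatter), and an at least 30-fold higher number from compound 2 to compound 3 (1.47 log units; beyond the scatter). Compound 4, `Cc1cnc(Nc2ccc(N3CCCCC3)cc2)nc1Nc1nc2ccccc2s1`, differs from compound 3 by one change: piperidin-1-yl in place of fluoro on an aromatic carbon. Both measured steps that bear on this change concern the same carbon and show that the fluoro compound sits far above the nitro and sulfamoyl compounds, the latter step large. Read in reverse, leaving fluoro for another group has lowered the number each time, so a step down beyond the scatter is expected for compound 4, an at least 10-fold lower number from compound 3 to compound 4 (1.00 log units; beyond the scatter). Compound 4 is therefore estimated at 5000 nM, between 1000 nM and 40000 nM.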

Compound 4, half-maximal inhibitory concentration: 18700 nM
Estimate against measurement, compound 4: 3.7-fold (0.57 log units) below; measured number inside the range.
By their numbers in this assay, from the lowest: compound 2; then compound 1; then compound 4. At a limit, above all of these: compound 3.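

In this assay, piperidin-1-yl in place of fluoro on this aromatic carbon gives an at least 2.6-fold lower number from compound 3 to compound 4 (0.42 log units; beyond the scatter), and this step rests on a limit for compound 3: the limit of > 50000 nM in this assay, at which 1 of the 4 values shown sits. The piperidine compound still falls short of both compounds with the other groups, with a 3.0-fold higher number from compound 1 to compound 4 (0.47 log units; beyond the scatter) and an 11-fold higher number from compound 2 to compound 4 (1.05 log units; beyond the scatter). Leaving fluoro therefore does not by itself bring the number down to that of the nitro or sulfamoyl compound.

The compounds shown leave open whether a primary amine, a carboxylic acid or a morpholine ring on this carbon would match the sulfamoyl compound. They also leave open whether the ring carbons or the nitrogen of piperidin-1-yl set its place in the series.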